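Methylating the Amide Nitrogen of Compound 3

A few compounds are considered here, and "the series" means these few. Any claim that something is new, unique, unknown or untested is made for them only; others in the source may bear on it.

Compound 1 `C=CC[C@H]1C[C@]2([C@@H](C)Cc3ccc(OC)c(OC)c3)OCOC2=CC1=O` gives 110 nM in a functional assay on M14 cells (Homo sapiens) for antiproliferative activity, with a stated time of 72 h; on this read-out higher numbers stand for weaker inhibition and lower numbers for stronger inhibition.
Compound 2 `C=CC[C@H]1C[C@]2([C@@H](C)Cc3ccc(OC)cc3)OCOC2=CC1=O` gives 20 nM in this assay.
Compound 3 `C=CC[C@H]1C[C@]2([C@@H](C)Cc3ccc(OC)c(C(N)=O)c3)OCOC2=CC1=O` gives 12 nM in this assay.

Compound 3 has the lowest number of the three. Its distance to compound 1 is clear, a 9.2-fold lower number from compound 1 to compound 3 (0.96 log units; beyond the scatter), but its distance to compound 2 is not, a 1.7-fold lower number from compound 2 to compound 3 (0.22 log units; within the scatter), so the two cannot be ranked against each other. The third measured step, a 5.5-fold lower number from compound 1 to compound 2 (0.74 log units; beyond the scatter), likewise concerns the substituent on the aromatic carbon and not the amide.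

Compound 4 `C=CC[C@H]1C[C@]2([C@@H](C)Cc3ccc(OC)c(C(=O)NC)c3)OCOC2=CC1=O` differs from compound 3 by methyl in place of hydrogen on an amide-type nitrogen. Going by the values given here, no measured step touches this nitrogen: all three compare groups on the aromatic carbon, and the only one involving the carbamoyl group against hydrogen, a 1.7-fold lower number from compound 2 to compound 3 (0.22 log units; within the scatter), stays within the scatter. There is therefore no measured basis for expecting a shift beyond the scatter in this assay in either direction, and the expectation is a step of about a 1.3-fold higher number from compound 3 to compound 4 (0.10 log units; within the scatter). For compound 4 the estimated value in this assay is 15 nM, with a range from 5 nM to 45 nM.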

Compound 4, half-maximal inhibitory concentration: 1400 nM
Compound 4: middle estimate off by 93-fold (1.97 log units), on the low side; the whole stated range lies below it.
By their numbers in this assay, from the lowest: compounds 3 and 2 (each within the scatter of the next); then compound 1; then compound 4.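

In this assay, going by these compounds alone, the earlier steps showed only that the carbamoyl group on this aromatic carbon performs on a par with hydrogen, whereas this result shows that the amide nitrogen itself is highly sensitive: one added carbon, a methyl in place of the amide hydrogen, gives a very large step (a 120-fold higher number from compound 3 to compound 4 (2.07 log units; beyond the scatter)). The change also moves the compound past both other groups compared at this aromatic carbon, since methylcarbamoyl gives a clearly higher number than hydrogen (a 70-fold higher number from compound 2 to compound 4 (1.85 log units; beyond the scatter)) and than methoxy (a 13-fold higher number from compound 1 to compound 4 (1.10 log units; beyond the scatter)), so the good result of compound 3 belongs to the unsubstituted carbamoyl group and does not extend to its methylated form. Nothing available explains why this one methyl has so large an effect.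

Still open, on these data alone, is whether any group on this nitrogen gives the same result, for example an ethyl group or a second methyl. Equally open, as far as these compounds go, is how other groups in place of the whole carbamoyl group, such as a carboxylic acid or a nitrile, would compare with compound 3 and compound 4.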